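Bromo-to-chloro exchange on the shared core: lipophilicity notes

The source may hold more compounds than are shown below. What is called first, only, known or untested is meant among the compounds shown, and "the series" means these compounds.

Compound 1 `Cc1cc(C#N)cc(C)c1Nc1nc(Nc2ccc(C#N)cc2)ncc1Br` and compound 2 `Cc1cc(C#N)cc(C)c1Oc1nc(Nc2ccc(C#N)cc2)ncc1Br` share a core; the difference between the two cores is not broken down here. In a physicochemical assay for lipophilicity (on this read-out higher numbers stand for higher lipophilicity and lower numbers for lower lipophilicity), compound 1 gives 1.64 and compound 2 gives 1.82. Compound 3 `Cc1cc(C#N)cc(C)c1Nc1nc(Nc2ccc(C#N)cc2)ncc1Cl` carries chloro in place of bromo on an aromatic carbon relative to compound 1, and in this assay compound 3 gives 1.37, so that a number 0.27 log units lower from compound 1 to compound 3 (within the scatter). Between compound 2 and compound 3 the gap lies beyond the scatter. Compound 4 `Cc1cc(C#N)cc(C)c1Oc1nc(Nc2ccc(C#N)cc2)ncc1Cl` is not yet measured in this assay; relative to compound 2 it carries chloro in place of bromo on an aromatic carbon, the same change at the same place as from compound 1 to compound 3, occurring twice among these four compounds. The expected step is a number 0.27 log units lower from compound 2 to compound 4 (within the scatter), resting on a number 0.27 log units lower from compound 1 to compound 3 (within the scatter) and on compound 2 giving 1.82. Compound 4 is therefore estimated at 1.55, between 1.25 and 1.85.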

Compound 4, partition coefficient: 1.54
Compound 4: middle estimate off by 0.01 log units, on the high side; the range from low to high includes it.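

In this assay, chloro in place of bromo on the aromatic carbon gives a number 0.28 log units lower from compound 2 to compound 4 (within the scatter), and on the core of compound 1 the same change gave a number 0.27 log units lower from compound 1 to compound 3 (within the scatter). Among these compounds, the step therefore carries from one core to the other at nearly the same size, but this rests on only two pairs, and neither step on its own stands clear of the scatter, so no real shift is established for either core. Nothing on hand bears on why the two steps match.

Open, from the compounds shown here alone, is how an amine, a fluoro or a methyl group at that aromatic carbon would read in this assay. Also open, going by these compounds, is whether the bromo-to-chloro step keeps its size on any further core.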